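Nitro in Place of Methyl on the Aryl Urea Ring

This account rests on a few compounds, and the source may have more. Where it says the series, first, only, none or still open, it means among the compounds named here.

Three compounds sharing one core have been examined in a functional assay on CRL2813 cells (Homo sapiens) for cytotoxicity, read by sulforhodamine B assay, with a stated time of 5 days; on this read-out higher numbers stand for weaker inhibition and lower numbers for stronger inhibition. Compound 1 `O=C(Nc1ccc(I)cc1)N[C@H]1CC[C@H](Oc2ccc(F)cc2)CC1` gives 10200 nM in this assay. Compound 2 `CSc1ccc(NC(=O)N[C@H]2CC[C@H](Oc3ccc(F)cc3)CC2)cc1` reaches only the limit of this assay, > 20000 nM, and so yields no number. Compound 3 `Cc1cccc(NC(=O)N[C@H]2CC[C@H](Oc3ccc(F)cc3)CC2)c1` gives 14400 nM in this assay, a number lying within the usual scatter of compound 1, as the step of a 1.4-fold higher number from compound 1 to compound 3 (0.15 log units; within the scatter) shows, while the step of an at least 1.3-fold lower number from compound 2 to compound 3 (0.14 log units; that floor lies within the scatter) rests on a limit of > 20000 nM in this assay, at which 1 of the 3 values shown sits, and likewise stays within the scatter.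

Compound 4 `O=C(Nc1cccc([N+](=O)[O-])c1)N[C@H]1CC[C@H](Oc2ccc(F)cc2)CC1` has not yet been measured. It differs from compound 3 as follows: nitro in place of methyl on an aromatic carbon. Cut one bond further out, the change reads 3-methylphenyl to 3-nitrophenyl on the amide-type nitrogen.

Within the data shown here, the steps that bear on this exchange are those altering the aryl group on the amide-type nitrogen, a 1.4-fold higher number from compound 1 to compound 3 (0.15 log units; within the scatter) and an at least 1.3-fold lower number from compound 2 to compound 3 (0.14 log units; that floor lies within the scatter), and both sit within the scatter. Among the measured compounds shown here, no measured step introduces a nitro group. For the measured compounds named here, the numbers so far suggest that changing this aryl group moves the readout little, so no step beyond the scatter is expected in this assay. Compound 4 is therefore estimated to give 14000 nM, between 7000 nM and 28000 nM. That estimate amounts to an expected step of a 1.0-fold lower number from compound 3 to compound 4 (0.01 log units; within the scatter).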

Compound 4, half-maximal inhibitory concentration: 6700 nM
Beside the measured number, compound 4's estimate is 2.1-fold (0.32 log units) above it, and the stated range ends above it.
By their numbers in this assay, from the lowest: compounds 4, 1 and 3 (each within the scatter of the next, the first and the last beyond it). At a limit, above all of these: compound 2.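

In this assay, among these compounds, the exchange of methyl for nitro on an aromatic carbon, meta to a large group, is the first change to this aryl group that moves the read-out beyond the scatter: a 2.1-fold lower number from compound 3 to compound 4 (0.33 log units; beyond the scatter). The gain is not uniform across the aryl groups compared, since a 1.5-fold lower number from compound 1 to compound 4 (0.18 log units; within the scatter) stays within the scatter, so the 3-nitrophenyl and 4-iodophenyl groups cannot be told apart here, whereas an at least 2.9-fold lower number from compound 2 to compound 4 (0.47 log units; beyond the scatter) lies beyond it. Compound 2 stands at a limit of the assay and not at a number, so that last step is only a floor: the limit of > 20000 nM in this assay, at which 1 of the 4 values shown sits.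

The compounds shown leave open whether the lower number is particular to nitro or would also appear with an amine, a nitrile or a carboxylic acid on the same aromatic carbon. They also leave open what a nitro group would do on a different carbon of this ring, and no measurement here ties the step to any property of the group.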